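The compounds below may be only part of what the source reports. "The series", "measured", "known", "first", "only" and "open" are said of these compounds alone.

Compound 1 `O=C1CC(c2nc(-c3cccc(Cl)c3)no2)CN1c1ccc(Cl)cc1`: 140 nM
Compound 2 `O=C1CC(c2nc(-c3cccc(Cl)c3)no2)CN1c1ccc(Cl)c(Cl)c1`: 460 nM
Compound 3 `O=C1CC(c2nc(-c3cccc(F)c3)no2)CN1c1ccc(Cl)c(Cl)c1`: 3200 nM

Of the compounds shown here, three built on one shared core have been tested in an in vitro functional assay on HEK293-A cells for positive allosteric modulation of metabotropic glutamate receptor 5 (Homo sapiens), read by FLIPR and calcium flux; a higher number here means that more compound is needed for the effect, a lower number that less compound is needed. Compound 1 gives 140 nM, compound 2 gives 460 nM, and compound 3 gives 3200 nM. Compound 2 and compound 1 differ by hydrogen in place of chloro on an aromatic carbon; that change produced a 3.3-fold lower number from compound 2 to compound 1 (0.52 log units; beyond the scatter). The cores of compound 2 and compound 3 differ by fluoro in place of chloro on an aromatic carbon, and this change produced a 7.0-fold higher number from compound 2 to compound 3 (0.84 log units; beyond the scatter), which leaves compound 3 with the highest number of the three, beyond the scatter against both others.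

Compound 4 `O=C1CC(c2nc(-c3cccc(F)c3)no2)CN1c1ccc(Cl)cc1` has not yet been measured. It differs from compound 3 by hydrogen in place of chloro on an aromatic carbon. Among the measured compounds shown here, this is the same change as the one from compound 2 to compound 1, made on the same place of the ring. The expectation for compound 4 therefore rests on carrying the step of a 3.3-fold lower number from compound 2 to compound 1 (0.52 log units; beyond the scatter) over to compound 3. For compound 4 the expected step is a 3.3-fold lower number from compound 3 to compound 4 (0.52 log units; beyond the scatter). In this assay compound 4 is estimated at 970 nM, expected to fall between 400 nM and 2500 nM.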

Compound 4, half-maximal effective concentration: 630 nM
For compound 4 the middle estimate is 1.5-fold (0.19 log units) above the measured one, within the range that was stated.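

Going from 3,4-dichlorophenyl to 4-chlorophenyl gave a 5.1-fold lower number from compound 3 to compound 4 (0.71 log units; beyond the scatter) in this assay, and the change kept its size on the second core: the same change on two cores in this assay, a 3.3-fold lower number (0.52 log units; beyond the scatter) from compound 2 to compound 1 and a 5.1-fold lower number (0.71 log units; beyond the scatter) from compound 3 to compound 4, 1.5-fold (0.19 log units) apart, within the scatter of two such steps. Fluoro in place of chloro on an aromatic carbon gave a 4.5-fold higher number from compound 1 to compound 4 (0.65 log units; beyond the scatter), which also matches its earlier step: the same change on two cores in this assay, a 7.0-fold higher number (0.84 log units; beyond the scatter) from compound 2 to compound 3 and a 4.5-fold higher number (0.65 log units; beyond the scatter) from compound 1 to compound 4, 1.5-fold (0.19 log units) apart, within the scatter of two such steps. Within these four compounds, each change therefore carried over from one core to the other, but the two comparisons draw on the same four values and so count as a single observation, which does not show that either change would carry over to a core altered anywhere else.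

The compounds shown leave open whether the same holds for other groups in these places, such as a methoxy group, a nitrile or a trifluoromethyl group in place of the chloro. They also leave open what an amine or a carboxylic acid on either aromatic ring would do to these steps.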